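Swapping an allyl for a methylphenyl on the amine nitrogen

The source may hold more compounds than are shown below. What is called first, only, known or untested is meant among the compounds shown, and "the series" means these compounds.

Measured compounds:
- Compound 1, `COc1ccc(Nc2nnc(-c3cc(-c4ccc(F)cc4F)ccc3O)o2)cc1`, with 35.3%
- Compound 2, `C=CCNc1nnc(-c2cc(-c3ccc(F)cc3F)ccc2O)o1`, with 36.6%

The read-out throughout is a functional assay on the whole organism (strain BALB/c) for inhibition, with Mus musculus as the target, read by paw edema, with a stated time of 4 h, at a dose of 50 mg/kg by the oral route; on this read-out lower numbers stand for less inhibition and higher numbers for more inhibition at the one dose given (going by the name of the read-out). On this read-out compound 2 holds the higher of the two numbers shown, but its neighbour compound 1 sits close: a number 1.3 percentage points higher from compound 1 to compound 2 (within the scatter), so the two cannot be told apart.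

The next compound, compound 3, `Cc1ccc(Nc2nnc(-c3cc(-c4ccc(F)cc4F)ccc3O)o2)cc1`, carries a change at the same nitrogen: 4-methylphenyl in place of allyl on a nitrogen on an aromatic ring.

For the measured compounds named here, only one measured step touches this position, the exchange of a substituted phenyl for allyl between compound 1 and compound 2, and it stayed within the scatter. Compound 3 moves back from allyl to a substituted phenyl, differing from the group in compound 1 only in the group at the far end of that ring. The expectation is therefore that the step of a number 1.1 percentage points lower from compound 2 to compound 3 (within the scatter) shows no change beyond the scatter.

For compound 3 the estimate in this assay is 35.5%, with a range from 25% to 46%.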

Compound 3, a percentage reported as inhibition, in the whole organism at one dose (the size of the read-out at that dose, not a potency): 33.8%
Estimate against measurement, compound 3: 1.7 percentage points above; measured number inside the range.
By their numbers in this assay, from the lowest: compounds 3, 1 and 2 (each within the scatter of the next).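

In this assay, replacing allyl with 4-methylphenyl on the nitrogen gives a number 2.8 percentage points lower from compound 2 to compound 3 (within the scatter), so a second substituted phenyl group also cannot be told apart from allyl. The new compound also adds a comparison within the phenyl ring: methyl in place of methoxy on an aromatic carbon gives a number 1.5 percentage points lower from compound 1 to compound 3 (within the scatter), which means that this exchange on the ring cannot be separated either. No supporting measurement is available to explain why these numbers sit so close together.

Going by these compounds, it remains open whether a longer chain in place of allyl, or a carboxylic acid in place of methyl on the aromatic carbon, would move the number beyond the scatter. With only one dose shown, these percentages also leave the relative potency of the three compounds unknown.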